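Changing the Ester Side Chain of Compound 1

A few compounds are considered here, and "the series" means these few. Any claim that something is new, unique, unknown or untested is made for them only; others in the source may bear on it.

Compound 1 `CC(=O)OCCC(=O)O[C@H](CC=C(C)C)C1=CC(=O)c2c(O)ccc(O)c2C1=O` gives 15700 nM in a functional assay on DU-145 cells (Homo sapiens) for cytotoxicity, read by MTT assay; on this read-out higher numbers stand for weaker inhibition and lower numbers for stronger inhibition.
Compound 2 `CCC(O)CO[C@H](CC=C(C)C)C1=CC(=O)c2c(O)ccc(O)c2C1=O` gives 16400 nM in this assay.
Compound 3 `CC(C)=CC[C@@H](OCCO)C1=CC(=O)c2c(O)ccc(O)c2C1=O` gives 9900 nM in this assay.

Compound 1 stands second highest of the three numbers, with a 1.0-fold higher number from compound 1 to compound 2 (0.02 log units; within the scatter) and a 1.6-fold lower number from compound 1 to compound 3 (0.20 log units; within the scatter); both of these steps lie within the scatter. Compound 4 `CC(C)=CC[C@@H](OC(=O)CC(C)(O)c1ccccc1)C1=CC(=O)c2c(O)ccc(O)c2C1=O` is not yet measured. It differs from compound 1 by 1-hydroxy-1-phenylethyl in place of acetoxymethyl on a saturated chain carbon bound to a carbonyl carbon. The two measured steps from compound 1 both replace the group on the same oxygen on a saturated carbon and neither moved the number beyond the scatter, so no step beyond the scatter is expected here either in this assay. Compound 4 is therefore estimated to give 14000 nM, with a range from 6000 nM to 33000 nM, which means an expected 1.1-fold lower number from compound 1 to compound 4 (0.05 log units; within the scatter).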

Compound 4, half-maximal inhibitory concentration: > 100000 nM
Compound 4: only a limit was reported; the forecaster's own chance of this, stated with the estimate: 5%; middle value at least 7.1-fold (0.85 log units) from the limit.
By their numbers in this assay, from the lowest: compounds 3, 1 and 2 (each within the scatter of the next). At a limit, above all of these: compound 4.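

Putting 1-hydroxy-1-phenylethyl in place of acetoxymethyl on a saturated chain carbon bound to a carbonyl carbon gives an at least 6.3-fold higher number from compound 1 to compound 4 (0.80 log units; beyond the scatter) in this assay. For the compounds shown here, this is the first step beyond the scatter, so the ester side chain can matter here, whereas the earlier replacements on the oxygen moved the number by no more than the scatter. The value for compound 4 is a limit, not a number: the limit of > 100000 nM in this assay, at which 1 of the 4 values shown sits.

The compounds shown do not separate the effect of the aromatic ring from that of the hydroxyl in the entering group. As far as these compounds go, how an amine or a carboxylic acid would read at this place also remains open.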